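From compound 3 to compound 4: an aryl group exchanged

The source may report more compounds than this note shows. Statements on the series, on what has been measured and on what is new or still open speak of the compounds shown alone.

Measured in a functional assay on MDA-MB-231 cells (Homo sapiens) for antiproliferative activity, read by MTT assay, with a stated time of 72 h; on this read-out higher numbers stand for weaker inhibition and lower numbers for stronger inhibition:
Compound 1 `O=C(CCc1cccc2c1B(O)OC2)Nc1cccc(-c2cccc(F)c2)c1`: 570 nM
Compound 2 `O=C(CCc1cccc2c1B(O)OC2)Nc1cccc(-c2cccc(OC(F)(F)F)c2)c1`: 460 nM
Compound 3 `CSc1ccc(-c2cccc(NC(=O)CCc3cccc4c3B(O)OC4)c2)cc1`: 140 nM

Compound 3 has the lowest number of the three, well clear of the other two. Compound 4 `O=C(CCc1cccc2c1B(O)OC2)Nc1cccc(-c2cccc(C(F)(F)F)c2)c1` has not yet been measured. It carries 3-(trifluoromethyl)phenyl in place of 4-(methylsulfanyl)phenyl on an aromatic carbon on the same shared core.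

Among the measured compounds shown here, two measured steps bear on this change. Introducing 4-(methylsulfanyl)phenyl in place of 3-fluorophenyl gave a 4.1-fold lower number from compound 1 to compound 3 (0.61 log units; beyond the scatter), a modest step beyond the scatter. Trifluoromethoxy in place of fluoro gave only a 1.2-fold lower number from compound 1 to compound 2 (0.09 log units; within the scatter), which lies within the scatter. Leaving 4-(methylsulfanyl)phenyl should therefore give back a similar modest step, towards weaker inhibition, and the expected size is a 3.4-fold higher number from compound 3 to compound 4 (0.54 log units; beyond the scatter). Compound 4 is estimated at 480 nM (range 220 nM to 1000 nM).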

Compound 4, half-maximal inhibitory concentration: 410 nM
Compound 4: the middle estimate sits 1.2-fold (0.07 log units) above what was measured, within the range that was stated.
By their numbers in this assay, from the lowest: compound 3; then compounds 4, 2 and 1 (each within the scatter of the next).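

In this assay, 3-(trifluoromethyl)phenyl in place of 4-(methylsulfanyl)phenyl gives a step beyond the scatter (a 2.9-fold higher number from compound 3 to compound 4 (0.47 log units; beyond the scatter)), so compound 3 now stands apart from three compounds rather than two. Trifluoromethyl matches trifluoromethoxy (a 1.1-fold lower number from compound 2 to compound 4 (0.05 log units; within the scatter)) and fluoro (a 1.4-fold lower number from compound 1 to compound 4 (0.14 log units; within the scatter)), leaving these three groups indistinguishable at this position. No available evidence explains these results.

From the compounds shown here alone, compound 3 differs from compound 4 in both its group and that group's place on the ring, so which of these matters stays open. Going by these compounds, how an amine or a carboxylic acid would behave on this aryl ring also remains open.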